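Swapping a methylpyridine arm for thiophene in compound 4

The source may report more compounds than this note shows. Statements on the series, on what has been measured and on what is new or still open speak of the compounds shown alone.

Compound 1 `Cc1cc(OCc2ccccn2)n2nc(C)c(-c3ccccc3)c2n1` and compound 2 `Cc1cc(NCc2nccn2C)n2nc(C)c(-c3ccccc3)c2n1` share a core with compound 3 `Cc1cccc(CNc2cc(C)nc3c(-c4ccccc4)c(C)nn23)n1`. In a physicochemical assay for solubility, read by HPLC, using the shake flask method, measured as kinetic solubility, with a stated time of 2 h, at pH 7.4 (a lower number here means a less soluble compound, a higher number a more soluble compound), compound 1 gives 25600 nM, and compound 2 gives 26900 nM; the step of a 1.1-fold higher number from compound 1 to compound 2 (0.02 log units; within the scatter) stays within the scatter. For compound 3 this assay reports only a limit, < 5000 nM, so compound 3 stands at the bottom of the numbers shown, as described by the limit of < 5000 nM in this assay, at which 1 of the 3 values shown sits. The step of an at least 5.3-fold lower number from compound 2 to compound 3 (0.73 log units; beyond the scatter) is the only one beyond the scatter. Compound 4 `Cc1cc(NCc2cccs2)n2nc(C)c(-c3ccccc3)c2n1` differs from compound 3 by thiophen-2-yl in place of 6-methylpyridin-2-yl on a saturated chain carbon bound to a nitrogen on an aromatic ring. Among the measured compounds shown here, no measured step exchanges one aromatic arm for another of this kind on that chain carbon, so the measured steps bear on it only loosely: the step from compound 2 to compound 3 shows that this position can move solubility beyond the scatter, in either direction. Compound 4 is therefore expected to sit near the limit, with an estimated step that the limit leaves unreadable from compound 3 to compound 4 and an estimated value 3500 nM between 1000 nM and 12000 nM in this assay.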

Compound 4, solubility: < 5000 nM
Compound 4 was reported as a limit (the forecaster's own chance of this, stated with the estimate: 60%); the middle value lies beyond the limit too.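

The replacement of 6-methylpyridin-2-yl by thiophen-2-yl on this saturated chain carbon gives a second arm that stands clearly apart from the two more soluble compounds in this assay: the data show an at least 5.3-fold lower number from compound 2 to compound 4 (0.73 log units; beyond the scatter), and also an at least 5.1-fold lower number from compound 1 to compound 4 (0.70 log units; beyond the scatter). The step between compound 3 and compound 4 cannot be read, so these two arms cannot be placed in order. Both values are limits, and the low end of this small set now holds two compounds: the limit of < 5000 nM in this assay, at which 2 of the 4 values shown sit.

The compounds shown leave open how far beneath the limit compound 3 and compound 4 actually lie. They also leave open whether an arm carrying a morpholine or a carboxylic acid on this chain carbon would return to the range of compound 2.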